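A few compounds are considered here, and "the series" means these few. Any claim that something is new, unique, unknown or untested is made for them only; others in the source may bear on it.

Measured compounds:
Compound 1 `COc1cc(-c2ccc3ncn(-c4cc(OC)c(OC)c(OC)c4)c3c2)cc(OC)c1OC`: > 10000 nM
Compound 2 `COc1cc(-n2cnc3ccc(-c4ccc(C(F)(F)F)cc4)cc32)cc(OC)c1OC`: 3390 nM

Of the compounds shown here, two have been measured in a functional assay on A549 cells (Homo sapiens) for antiproliferative activity, read by MTT assay, with a stated time of 72 h; on this read-out higher numbers stand for weaker inhibition and lower numbers for stronger inhibition. Compound 1 gives > 10000 nM, which is a limit of the assay and not a number; it sits at the limit of > 10000 nM in this assay, at which 1 of the 2 values shown sits. Going by the values given here, compound 2 gives 3390 nM, the only actual number among the two values, so there is no measured step between compounds to lean on.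

Compound 3 `COc1cc(-n2cnc3ccc(-c4cc(F)ccc4F)cc32)cc(OC)c1OC` differs from compound 2 in one place: 2,5-difluorophenyl in place of 4-(trifluoromethyl)phenyl on an aromatic carbon. Among the compounds with values here, no measured pair differs in this way, so the size of such a step is not known from these data. In this assay the step is expected to be small, a 1.5-fold higher number from compound 2 to compound 3 (0.17 log units; within the scatter), close to the usual scatter and, if anything, toward weaker inhibition. Compound 3 is therefore estimated at 5000 nM, with a range from 1500 nM to 15000 nM.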

Compound 3, half-maximal inhibitory concentration: 7940 nM
The estimate for compound 3 lay 1.6-fold (0.20 log units) below the measured number; low and high end bracket the measured number.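

Going by these compounds alone, this is the first measured step at this position: in this assay, putting 2,5-difluorophenyl in place of 4-(trifluoromethyl)phenyl gives a 2.3-fold higher number from compound 2 to compound 3 (0.37 log units; beyond the scatter), which shows that the choice of substituted phenyl group here can change the read-out. This single step cannot separate the loss of the trifluoromethyl group from the arrival of the two fluorines, as both changes come together. Compound 1 is recorded only as a limit, not a number, and provides no measured step to set beside this one: the limit of > 10000 nM in this assay, at which 1 of the 3 values shown sits.

As far as these compounds go, it remains open how this position would respond to a different kind of group, such as an amine, a carboxylic acid or an unsubstituted phenyl ring. From the compounds shown here alone, whether any replacement here would give stronger inhibition than compound 2 also remains unknown.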